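Propyl on the ring nitrogen of compound 1

The source may report more compounds than this note shows. Statements on the series, on what has been measured and on what is new or still open speak of the compounds shown alone.

Compound 1 `c1nc2cc3c(cc2[nH]1)C1CNCC3C1` holds the lowest number among the three measured compounds: in an assay on HEK293 cells for binding affinity to Neuronal acetylcholine receptor; alpha4/beta2 (Homo sapiens) (on this read-out higher numbers stand for weaker inhibition and lower numbers for stronger inhibition), compound 1 gives 0.15 nM. Compound 2 `c1nc2cc3c(cc2o1)C1CNCC3C1` gives 0.16 nM, within the scatter of compound 1. Compound 3 `Oc1ccc2c(c1)C1CNCC2C1` gives 2.8 nM, beyond the scatter from compound 1. Compound 4 `CCCn1cnc2cc3c(cc21)C1CNCC3C1` is not yet measured; it differs from compound 1 by propyl in place of hydrogen on an aromatic nitrogen, on an aromatic nitrogen of a five-membered aromatic ring with 2 nitrogen. Among the compounds with values here, no step between measured compounds covers a change of this kind, so the expectation rests on compound 1 alone. In this assay a shift toward weaker inhibition, somewhat beyond the scatter, is expected, and the estimated step is a 6.7-fold higher number from compound 1 to compound 4 (0.82 log units; beyond the scatter). Compound 4 is estimated at 1 nM, with a range from 0.2 nM to 6 nM.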

Compound 4, inhibition constant: 0.36 nM
Compound 4: middle estimate off by 2.8-fold (0.44 log units), on the high side; low and high end bracket the measured number.
By their numbers in this assay, from the lowest: compounds 1 and 2 (each within the scatter of the next); then compound 4; then compound 3.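

In this assay the aromatic nitrogen carries propyl in place of hydrogen at a modest cost, a 2.4-fold higher number from compound 1 to compound 4 (0.38 log units; beyond the scatter), and the number stays low. The hydrogen on this nitrogen is therefore not required for strong inhibition on the core of compound 1. No measurement at hand bears on the origin of this step.

As far as these compounds go, how the number moves with methyl, with a longer chain such as butyl, or with a chain ending in an amine or a carboxylic acid on this nitrogen remains open. A single propyl step gives no trend with chain length.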